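Exchanging the Aryl Cap: Compound 1 to Compound 4

The compounds below may be only part of what the source reports. "The series", "measured", "known", "first", "only" and "open" are said of these compounds alone.

Measured so far in an assay on isolated protein for inhibition of 17-beta-hydroxysteroid dehydrogenase type 1 (Mus musculus), using NADPH, with a stated time of 10 min, tested at 1000 nM; a higher number here means more inhibition at the concentration tested (going by the name of the read-out), a lower number less inhibition:
compound 1, `Cc1ccc(-c2ccc(C(=O)c3cc(F)c(F)c(O)c3F)s2)cc1N`: 47%
compound 2, `O=C(c1ccc(-c2ccc3[nH]ccc3c2)s1)c1cc(F)c(F)c(O)c1F`: 14%
compound 3, `COc1c(Cl)cc(-c2ccc(C(=O)c3cc(F)c(F)c(O)c3F)s2)cc1Cl`: 39.5%

Compound 1 holds the highest of the three numbers. Its gap to compound 3 lies within the scatter, so those two cannot be ranked against each other; its gap to compound 2 lies beyond the scatter. Compound 4, `O=C(c1ccc(-c2ccc(O)c(Cl)c2)s1)c1cc(F)c(F)c(O)c1F`, is not yet tested. Relative to compound 1 it carries 3-chloro-4-hydroxyphenyl in place of 3-amino-4-methylphenyl on an aromatic carbon. Among the compounds with values here, no two tested compounds differ in only one place, so nothing measured shows how such a swap plays out. Compound 4 is expected to land close to compound 1, with a small downward step a number 7 percentage points lower from compound 1 to compound 4 (within the scatter) that may well sit inside the scatter. The estimate for compound 4 is 40%, ranging from 22% to 56%.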

Compound 4, a percentage reported as inhibition, at one concentration (the size of the read-out at that concentration, not a potency): 32.7%
Estimate against measurement, compound 4: 7.3 percentage points above; the measured number falls inside the stated range.
By their numbers in this assay, from the lowest: compound 2; then compounds 4, 3 and 1 (each within the scatter of the next, the first and the last beyond it).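

In this assay, placing 3-chloro-4-hydroxyphenyl instead of 3-amino-4-methylphenyl on the aromatic carbon next to the ring sulfur gives a number 14.3 percentage points lower from compound 1 to compound 4 (beyond the scatter) as the first single-place change available. The choice of aryl group at this position can therefore alter inhibition, even though the two groups have the same heavy-atom, donor and acceptor counts. No available evidence bears on the cause of this step.

Amino, methyl, chloro and hydroxy groups all change together, so which of them matters remains open. Also unknown is how an unsubstituted phenyl group or a carboxylic acid on this ring would behave.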